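The source may report more compounds than this note shows. Statements on the series, on what has been measured and on what is new or still open speak of the compounds shown alone.

Compound 1 `CCCCOC(=O)Nc1cc2nc(C3CCCCC3)[nH]c2cc1N(CC)CCN(C)C` is the starting point. In an ADME assay on Vero cells (Chlorocebus sabaeus) for cytotoxicity, read by resazurin assay, with a stated time of 3 days (a higher number here means a weaker inhibitor, a lower number a stronger inhibitor), compound 1 gives no number but a limit of the assay, > 100 ug/mL. The two other measured compounds stand the same way. Compound 2 `CCOCCOC(=O)Nc1cc2nc(C3CCCCC3)[nH]c2cc1N1CCCC1` gives in this assay only the limit > 100 ug/mL. Compound 3 `COc1ccc(C(=O)Nc2cc3nc(C4CCCCC4)[nH]c3cc2N2CCCC2)cc1` gives in this assay only the limit > 100 ug/mL. For the measured compounds named here, the one step that can be drawn between measured compounds, a step that the two limits leave unreadable from compound 2 to compound 3, is therefore of unreadable size. Going by the values given here, all that is known is summed up in the limit of > 100 ug/mL in this assay, at which 3 of the 3 values shown sit: no measured compound reaches a number in this assay.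

Compound 4 `CCCCOC(=O)Nc1cc2nc(C3CCCCC3)[nH]c2cc1N(CC)CC` differs from compound 1 by hydrogen in place of dimethylamino on a saturated chain carbon, two bonds along the chain from a nitrogen on an aromatic ring. Among the compounds with values here, no measured step touches this change, since neither compound 2 nor compound 3 carries the (2-(dimethylamino)ethyl)(ethyl)amino group, and the only step that exists is unreadable. The expectation therefore rests on where compound 1 stands. Compound 4 is expected to stay at the same limit, the step of a number no higher from compound 1 to compound 4 (the limit leaves the size open) being estimated as none beyond the scatter. The estimate for compound 4 in this assay is 100 ug/mL, between 50 ug/mL and 200 ug/mL, with the likeliest result once again only a limit.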

Compound 4, half-maximal inhibitory concentration: > 100 ug/mL
Compound 4 was reported as a limit; the forecaster's own chance of this, stated with the estimate: 80%; the middle value lies on the limit itself.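

Compound 1 and compound 4 both give only a limit, so no step between them can be read in this assay: the limit of > 100 ug/mL in this assay, at which 4 of the 4 values shown sit.

The compounds shown leave open how far any of them lies from that limit, and whether hydrogen in place of dimethylamino changes the cytotoxicity reading at all.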